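The compounds below may be only part of what the source reports. "The series", "measured", "known", "first", "only" and "open" are said of these compounds alone.

In a functional assay on KYSE-450 cells (Homo sapiens) for inhibition, read by CCK-8 assay, with a stated time of 48 h (a lower number here means a stronger inhibitor, a higher number a weaker inhibitor), compound 1 `CCN1CCN(C(=S)SCC(=O)N(Cc2ccc(OC)cc2)c2cc(OC)c(OC)c(OC)c2)CC1` gives 3070 nM. Compound 3 `COc1ccc(CN(C(=O)CSC(=S)N2CCCc3cc(OC)ccc32)c2cc(OC)c(OC)c(OC)c2)cc1` gives 5530 nM, and a 1.8-fold higher number from compound 1 to compound 3 (0.26 log units; within the scatter) stays inside the usual scatter. Compound 2 `COc1ccc(CN(C(=O)CSC(=S)N2CCc3cc(Br)ccc32)c2cc(OC)c(OC)c(OC)c2)cc1` reads > 20000 nM, which is a limit of the assay and not a number. That limit still marks an at least 6.5-fold higher number from compound 1 to compound 2 (0.81 log units; beyond the scatter).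

Compound 4 `CCN1CCN(C(=S)SCC(=O)N(Cc2ccc(OC)c(O)c2)c2cc(OC)c(OC)c(OC)c2)CC1` differs from compound 1 by hydroxy in place of hydrogen on an aromatic carbon, turning 4-methoxybenzyl into 3-hydroxy-4-methoxybenzyl. Every measured step changes the group on the thiocarbonyl carbon, so none of them gives a size for this change. The estimate therefore stays anchored on compound 1 at 3070 nM. The expected result is a 1.9-fold lower number from compound 1 to compound 4 (0.28 log units; within the scatter), with no step beyond the scatter. For compound 4, the estimated value is 1600 nM, with an expected range from 200 nM to 6000 nM.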

Compound 4, half-maximal inhibitory concentration: 320 nM
Compound 4: middle estimate off by 5.0-fold (0.70 log units), on the high side; measured number inside the range.
By their numbers in this assay, from the lowest: compound 4; then compounds 1 and 3 (each within the scatter of the next). At a limit, above all of these: compound 2.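

Every earlier step changed the group on the thiocarbonyl carbon, whereas here, in this assay, turning 4-methoxybenzyl into 3-hydroxy-4-methoxybenzyl gives a 9.6-fold lower number from compound 1 to compound 4 (0.98 log units; beyond the scatter). So this aromatic carbon, ortho to a methoxy group, responds strongly to the addition of one oxygen atom, a larger step than any measured number shows among the thiocarbonyl changes. Nothing shown here explains why the hydroxy group has this effect. On these data alone, whether an amine or a fluorine on the same carbon would do the same remains open. So does whether the hydroxy group helps equally with 6-methoxy-1,2,3,4-tetrahydroquinolin-1-yl on the thiocarbonyl carbon.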